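Halogen swap on the benzoyl ring of compound 2

A few compounds are considered here, and "the series" means these few. Any claim that something is new, unique, unknown or untested is made for them only; others in the source may bear on it.

Three benzophenone analogues sharing one core have been read in a functional assay on THP-1 cells (Homo sapiens) for inhibition, read by ELISA, with stated times of 30 min and 24 h, tested at 10 uM; a higher number here means a stronger effect of the compound at the concentration tested, a lower number a weaker effect. Compound 1 `COc1cc(O)c(C(=O)c2cccc(F)c2)c(OC)c1` gives 81%. Compound 2 `COc1cc(O)c(C(=O)c2ccccc2Br)c(OC)c1` gives 72%, the smallest of the three numbers; the gap to compound 1 lies within the scatter, while compound 3 `COc1cc(OC)c(C(=O)c2ccccc2Br)c(O)c1CN1CCCCC1`, at 98%, lies beyond it. For the measured compounds named here, the one measured step, a number 26 percentage points higher from compound 2 to compound 3 (beyond the scatter), concerns a (piperidin-1-yl)methyl entering on an aromatic carbon and says nothing about the halogen.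

Compound 4 `COc1cc(O)c(C(=O)c2ccccc2F)c(OC)c1` differs from compound 2 by fluoro in place of bromo on an aromatic carbon. Going by the values given here, no measured step bears on this change. Compound 1 carries fluoro on the same ring, and its value against compound 2 is within the scatter, so no step beyond the scatter is expected in this assay. The change from compound 2 to compound 4 is therefore estimated at a number 4 percentage points higher from compound 2 to compound 4 (within the scatter). Compound 4 is expected to give about 76%, within a range of 60% to 90%.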

Compound 4, a percentage reported as activity, at one concentration (the size of the read-out at that concentration, not a potency): 71%
The estimate for compound 4 lay 5 percentage points above the measured number; low and high end bracket the measured number.
By their numbers in this assay, from the lowest: compounds 4, 2 and 1 (each within the scatter of the next); then compound 3.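

In this assay, fluoro in place of bromo on an aromatic carbon, ortho to a large group, gives a number 1 percentage points lower from compound 2 to compound 4 (within the scatter) and so leaves the read-out at this concentration unmoved beyond the scatter. For the compounds shown here, this is the first measured step at the halogen itself, since the earlier step concerned only the (piperidin-1-yl)methyl, and it shows that these two halogens can stand in for each other at this place on the shared core. No evidence is available that bears on why they read alike.

Still open, as far as these compounds go, is whether a larger or different group at this place, such as a methoxy group, a nitrile or a carboxylic acid, would move the read-out beyond the scatter. From the compounds shown here alone, it is also open whether the same swap would read alike with the (piperidin-1-yl)methyl present, as in compound 3.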